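Sulfonamide nitrogen substituents on the shared core

The source may report more compounds than this note shows. Statements on the series, on what has been measured and on what is new or still open speak of the compounds shown alone.

Measured so far:
compound 1 `CC[C@@H]1C(=O)N(C)c2cnc(Nc3ccc(S(N)(=O)=O)cc3)nc2N1C1CCCC1` — 3390 nM
compound 2 `CCCCNS(=O)(=O)c1ccc(Nc2ncc3c(n2)N(C2CCCC2)[C@H](CC)C(=O)N3C)cc1` — 477 nM
compound 3 `CC[C@@H]1C(=O)N(C)c2cnc(Nc3ccc(S(=O)(=O)NCC(C)C)cc3)nc2N1C1CCCC1` — 750 nM

In a functional assay on A549 cells (Homo sapiens) for antiproliferative activity, read by CCK-8 assay, with a stated time of 72 h (a higher number here means a weaker inhibitor of growth, a lower number a stronger inhibitor of growth), compound 3 gives 750 nM, the second highest of the three numbers. The nearest of the other numbers is reached by a 1.6-fold higher number from compound 2 to compound 3 (0.20 log units; within the scatter); the furthest by a 4.5-fold lower number from compound 1 to compound 3 (0.66 log units; beyond the scatter).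

Compound 4 `CC[C@@H]1C(=O)N(C)c2cnc(Nc3ccc(S(=O)(=O)NC)cc3)nc2N1C1CCCC1` is the next step from compound 3. The change is hydrogen in place of isopropyl on a saturated chain carbon bound to a sulfonamide nitrogen. For the measured compounds named here, two measured steps bear on it. Going from hydrogen to isobutyl on the sulfonamide nitrogen gave a 4.5-fold lower number from compound 1 to compound 3 (0.66 log units; beyond the scatter), and hydrogen to butyl gave a 7.1-fold lower number from compound 1 to compound 2 (0.85 log units; beyond the scatter); both are beyond the scatter and in the same direction. The swap between butyl and isobutyl, a 1.6-fold higher number from compound 2 to compound 3 (0.20 log units; within the scatter), is within the scatter, so the size of the branched chain mattered little once a chain was present. Methyl sits between hydrogen and isobutyl, so part of the gain seen in compound 3 is expected to be given back, but not all of it.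

Compound 4 is therefore expected to give about 1600 nM in this assay, within a range of 650 nM to 4000 nM. The expected step is a 2.1-fold higher number from compound 3 to compound 4 (0.33 log units; beyond the scatter), smaller than the full return to compound 1 at 3390 nM.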

Compound 4, concentration for 50% growth inhibition: 183 nM
Estimate against measurement, compound 4: 8.7-fold (0.94 log units) above; the whole stated range lies above it.
By their numbers in this assay, from the lowest: compound 4; then compounds 2 and 3 (each within the scatter of the next); then compound 1.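

In this assay, compound 4, with methyl on the sulfonamide nitrogen, has the lowest number of the series, and the gain over the unsubstituted sulfonamide is the largest seen at this position: a 19-fold lower number from compound 1 to compound 4 (1.27 log units; beyond the scatter). Shortening the chain therefore does not move the number back towards that of compound 1, as both a 4.1-fold lower number from compound 3 to compound 4 (0.61 log units; beyond the scatter) and a 2.6-fold lower number from compound 2 to compound 4 (0.42 log units; beyond the scatter) go the other way, so the response does not run steadily from hydrogen through to the longer chains, with compound 1 highest, compound 4 lowest, and compounds 2 and 3 within the scatter of each other in the middle. No measurement at hand accounts for this order.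

The compounds shown leave open whether ethyl or propyl on the sulfonamide nitrogen would stay with methyl or fall with butyl and isobutyl, which would locate where the number turns upward. Also open, from the compounds shown here alone, is whether a second methyl on that nitrogen, a cyclopropyl, or a chain ending in an amine or a carboxylic acid would hold the number of compound 4 at 183 nM.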